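Extending the chain on the S configured urea

The compounds below may be only part of what the source reports. "The series", "measured", "known", "first", "only" and "open" are said of these compounds alone.

Measured compounds in an ADME assay on the whole organism with Oryza sativa as the target, tested at 10 uM; a lower number here means a stronger effect, a higher number a weaker effect of the compound at the concentration tested:
compound 1, `CCc1ccc(NC(=O)N[C@H](C)c2ccccc2)cc1`, 44%
compound 2, `CCc1ccc(NC(=O)N[C@@H](C)c2ccccc2)cc1`, 91%
compound 3, `CCCCCCc1ccc(NC(=O)N[C@H](C)c2ccccc2)cc1`, 101%

Compound 2 holds the second highest of the three numbers. Its nearest neighbour is compound 3, whose number lies within the scatter of it, while compound 1 lies well below, the step of a number 47 percentage points higher from compound 1 to compound 2 (beyond the scatter) being large; the two compounds differ only in the configuration as drawn (the fact that compounds 1 and 2 differ only in the configuration as drawn).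

The compound still to be measured is compound 4, `CCCCCCCc1ccc(NC(=O)N[C@@H](C)c2ccccc2)cc1`. Compared with compound 2 the change is pentyl in place of hydrogen on a saturated chain carbon, two bonds along the chain from an aromatic carbon.

The measured step that bears on this change is a number 57 percentage points higher from compound 1 to compound 3 (beyond the scatter), where butyl in place of hydrogen at the same kind of chain carbon raised the number strongly. Compound 2, however, already stands high, so the room for a rise is limited, and the expectation is a step of a number 7 percentage points higher from compound 2 to compound 4 (within the scatter), small and not clearly beyond the scatter. Compound 4 is therefore expected to give 98%, with a range from 85% to 110%.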

Compound 4, a percentage reported as activity, at one concentration (the size of the read-out at that concentration, not a potency): 99%
Compound 4: middle estimate off by 1 percentage points, on the low side; the range from low to high includes it.
By their numbers in this assay, from the lowest: compound 1; then compounds 2, 4 and 3 (each within the scatter of the next).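

In this assay, pentyl in place of hydrogen on the S configured urea gives a number 8 percentage points higher from compound 2 to compound 4 (within the scatter), so this change at this chain carbon does not show the large rise seen on the R configured side, where the step was a number 57 percentage points higher from compound 1 to compound 3 (beyond the scatter). A long chain at this place therefore does not raise the number in every case; the large rise is confined to the pair that starts from the low value of compound 1, 44%. The two steps start from compounds of opposite drawn configuration, and those starting compounds are otherwise alike: the fact that compounds 1 and 2 differ only in the configuration as drawn

The compounds shown leave open whether a shorter addition such as methyl would keep the low number of compound 1. They also leave open whether an amine in place of pentyl would bring the number of compound 2 down.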